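The source may hold more compounds than are shown below. What is called first, only, known or untested is meant among the compounds shown, and "the series" means these compounds.

Compounds measured so far in an in vitro functional assay on 1321-N1 cells for agonist activity at Free fatty acid receptor 1 (Homo sapiens), read by fluorescence, spectrophotometry and calcium flux; a lower number here means a smaller maximal response, a higher number a larger maximal response:

Compound 1, `O=C(O)CCc1ccc(C#Cc2cncs2)cc1`, gives 99%.
Compound 2, `O=C(O)CCc1ccc(C#Cc2ccccn2)cc1`, gives 98%.
Compound 3, `O=C(O)CCc1ccc(C#Cc2ccncc2)cc1`, gives 100%.

All three compounds share the same core and differ only in the ring on the triple-bonded carbon. In this assay compound 2 gives the smallest of the three numbers, but its distance from each of the others lies within the scatter: the step of a number 1 percentage points lower from compound 1 to compound 2 (within the scatter) and the step of a number 2 percentage points higher from compound 2 to compound 3 (within the scatter) are both too small to count as a change, as is the step of a number 1 percentage points higher from compound 1 to compound 3 (within the scatter). On the numbers shown, compound 2 therefore stands level with compound 1 and compound 3.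

Compound 4, `Cc1cccc(C#Cc2ccc(CCC(=O)O)cc2)n1`, has not yet been measured. It differs from compound 2 by methyl in place of hydrogen on an aromatic carbon.

Going by the values given here, none of the measured steps involves a methyl group, so no step bears directly on this change. What the measured steps show is that the maximal response in this assay has not moved beyond the scatter when the ring on the triple-bonded carbon was exchanged, which makes a large step in this assay unlikely. Compound 4 is therefore expected to show a step of about no change at the digits printed from compound 2 to compound 4 (within the scatter), that is, none beyond the scatter. The estimate for compound 4 in this assay is 98%, with a range from 88% to 106%.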

Compound 4, largest response reached (reported as efficacy), in percent of the reference or control that the assay uses: 108%
The estimate for compound 4 lay 10 percentage points below the measured number, and the stated range ends below it.
By their numbers in this assay, from the lowest: compounds 2, 1, 3 and 4 (each within the scatter of the next).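

In this assay, going by these compounds alone, the earlier compounds differed only by exchange of the whole ring on the triple-bonded carbon, whereas compound 4 keeps the pyridin-2-yl ring of compound 2 and adds methyl in place of hydrogen on an aromatic carbon, next to the ring nitrogen, with a number 10 percentage points higher from compound 2 to compound 4 (within the scatter). This shows that, for this one pair, a single added carbon at this place leaves the maximal response level with that of the parent, so the position accepts a methyl group without a change that can be told from the scatter; substitution on the ring, and not only exchange of the ring, has now been seen to hold the response. Nothing in the data shown gives a measured property that bears on this result, so no explanation can be offered for it.

The compounds shown leave open whether a longer chain such as ethyl, or a methoxy group, an amine or a chlorine atom, would hold the response at this same place. They also leave open whether methyl on another carbon of this ring, or on the pyridin-4-yl or 1,3-thiazol-5-yl ring, would read the same way.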